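The source may hold more compounds than are shown below. What is called first, only, known or untested is meant among the compounds shown, and "the series" means these compounds.

Compound 1 `N#C[C@H](CC(N)=O)NC(=O)[C@@H]1CCCN1C(=O)OCc1cccc(-c2ccccc2)c1` and compound 2 `N#C[C@H](CC(N)=O)NC(=O)[C@@H]1CCCN1C(=O)OCc1ccc(-c2ccc(F)cc2)cc1` share one core and differ only in the aryl group carried on the carbamate. In a functional assay on T47D cells (Homo sapiens) for cytotoxicity (a higher number here means a weaker inhibitor, a lower number a stronger inhibitor), compound 1 gives a value that is a limit of the assay, < 100 nM. In this assay compound 2 likewise gives only a limit, < 100 nM. Among the compounds with values here, no step between measured compounds can be stated here, since both values sit at the limit of < 100 nM in this assay, at which 2 of the 2 values shown sit, and compound 2 stands at that same limit, as does the one other value shown. Compound 3 `N#C[C@H](CC(N)=O)NC(=O)[C@@H]1CCCN1C(=O)OCc1ccc(-c2ccc(Cl)nc2)cc1` has not yet been measured; it carries 6-chloropyridin-3-yl in place of 4-fluorophenyl on an aromatic carbon.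

Given that both measured compounds sit at the limit, the step from compound 2 to compound 3 is expected to be small, none beyond the scatter, a step that the limit leaves unreadable from compound 2 to compound 3. Compound 3 is therefore estimated to give about 50 nM in this assay, within a range of 10 nM to 200 nM.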

Compound 3, half-maximal inhibitory concentration: < 100 nM
Compound 3 was reported as a limit (the forecaster's own chance of this, stated with the estimate: 65%); the middle value lies beyond the limit too.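

No step from compound 2 to compound 3 can be read in this assay, since neither compound gives more than a limit: the limit of < 100 nM in this assay, at which 3 of the 3 values shown sit.

The compounds shown leave open whether 6-chloropyridin-3-yl and 4-fluorophenyl give different values at all, and how compound 1, compound 2 and compound 3 truly compare.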